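The compounds below may be only part of what the source reports. "The series", "measured", "known", "first", "only" and "open" are said of these compounds alone.

Measured so far. Compound 1 `CCNC(=O)[C@H]1O[C@@H](n2cnc3c(NNC(=O)c4ccccc4)ncnc32)[C@H](O)[C@@H]1O`: in an assay on CHO cells for displacement of a labelled ligand from adenosine receptor A1 (Homo sapiens) (a lower number here means a stronger inhibitor, a higher number a weaker inhibitor), compound 1 gives only a limit, > 5000 nM. Compound 2 `CCNC(=O)[C@H]1O[C@@H](n2cnc3c(NNC(=O)c4ccc(Br)o4)ncnc32)[C@H](O)[C@@H]1O`: compound 2 gives 780 nM. Compound 3 `CCNC(=O)[C@H]1O[C@@H](n2cnc3c(NNC(=O)c4ccccc4)nc(Cl)nc32)[C@H](O)[C@@H]1O`: compound 3 gives only a limit, > 5000 nM.

Compound 3 therefore stands at the limit of > 5000 nM in this assay, at which 2 of the 3 values shown sit, with no number to read.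

Compound 4 `CCNC(=O)[C@H]1O[C@@H](n2cnc3c(NNC(=O)c4ccco4)nc(Cl)nc32)[C@H](O)[C@@H]1O` differs from compound 3 by furan-2-yl in place of phenyl on a carbonyl carbon. For the measured compounds named here, one measured step bears on this: an at least 6.4-fold lower number from compound 1 to compound 2 (0.80 log units; beyond the scatter), where a related five-membered ring replaced phenyl on the same carbonyl carbon. The other step, a step that the two limits leave unreadable from compound 1 to compound 3, says nothing about the size of that move. A lower number is expected for compound 4; the step of an at least 1.6-fold lower number from compound 3 to compound 4 (0.22 log units; that floor lies within the scatter) is an estimate. The value for compound 4 is estimated at 3000 nM, within 700 nM to 12000 nM, and a limit remains a real possibility.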

Compound 4, inhibition constant: 3500 nM
Compound 4: middle estimate off by 1.2-fold (0.07 log units), on the low side; the measured number falls inside the stated range.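

In this assay, for the compounds shown here, furan-2-yl in place of phenyl on a carbonyl carbon gives the first readable number with chloro on the core, as an at least 1.4-fold lower number from compound 3 to compound 4 (0.15 log units; that floor lies within the scatter). That floor lies within the scatter, so this change alone is not shown to go beyond it. The true size of the step stays unknown because compound 3 sits at a limit: the limit of > 5000 nM in this assay, at which 2 of the 4 values shown sit.

Open, from the compounds shown here alone, is what 5-bromofuran-2-yl would give with the chloro kept. Also open, going by these compounds, is what an amine or a longer alkyl chain would give in place of furan-2-yl on the same carbonyl carbon.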